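The source may report more compounds than this note shows. Statements on the series, on what has been measured and on what is new or still open speak of the compounds shown alone.

Among the compounds with values here, in a functional assay on HL-60 cells (Homo sapiens) for inhibition, read by CCK-8 assay, with a stated time of 48 h, tested at 20 uM (on this read-out lower numbers stand for less inhibition of growth and higher numbers for more inhibition of growth at the one concentration tested), compound 3 (`COc1ccc(S(=O)(=O)Oc2ccccc2/C=C(\C#N)C(=O)Nc2nnc(Cc3cccc(F)c3)s2)cc1`) gives 100%, the highest of the three numbers so far. Compound 1 (`N#C/C(=C\c1ccccc1OS(=O)(=O)c1ccc([N+](=O)[O-])cc1)C(=O)Nc1nnc(-c2cccs2)s1`) gives 23%, and compound 2 (`N#C/C(=C\c1ccccc1OS(=O)(=O)c1ccc([N+](=O)[O-])cc1)C(=O)Nc1nnc(Cc2ccccc2)s1`) gives 20%. Compound 4 (`N#C/C(=C\c1ccccc1OS(=O)(=O)c1ccc([N+](=O)[O-])cc1)C(=O)Nc1nnc(Cc2cccc(F)c2)s1`) has not yet been measured. It differs from compound 3 at one place, with nitro in place of methoxy on an aromatic carbon, para to a large group: nitro in place of methoxy on an aromatic carbon. Within the data shown here, no measured step makes this exact change. The only one available, benzyl in place of thiophen-2-yl at another place, is small: a number 3 percentage points lower from compound 1 to compound 2 (within the scatter). The indirect evidence comes from the groups themselves: compound 1 and compound 2 carry the 4-nitrophenyl of compound 4, while compound 3 carries 4-methoxyphenyl. However, compound 4 keeps the fluorine of compound 3, which compound 2 lacks, so the data cannot separate the two changes and the uncertainty stays wide. A large downward step is expected, estimated as a number 65 percentage points lower from compound 3 to compound 4 (beyond the scatter). For compound 4 the expected value is 35%, with an estimated range of 15% to 80%.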

Compound 4, percent growth inhibition at one concentration: 18%
For compound 4 the middle estimate is 17 percentage points above the measured one, within the range that was stated.
By their numbers in this assay, from the lowest: compounds 4, 2 and 1 (each within the scatter of the next); then compound 3.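

In this assay, nitro in place of methoxy on an aromatic carbon, para to a large group, can now be read directly, with the rest of compound 3 unchanged, and it gives a number 82 percentage points lower from compound 3 to compound 4 (beyond the scatter) in growth inhibition. Among the nitro compounds, fluoro in place of hydrogen gives a number 2 percentage points lower from compound 2 to compound 4 (within the scatter) and 3-fluorobenzyl in place of thiophen-2-yl gives a number 5 percentage points lower from compound 1 to compound 4 (within the scatter) at the other end of the molecule, so the fluorine alone does not bring back the high reading of compound 3, and the gap that earlier could not be assigned now sits at this one position. No measurement in hand explains why this swap has so large an effect.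

On these data alone, only methoxy and nitro appear at this position, so how an amine, a chlorine or a plain hydrogen there would read stays open. All the evidence for methoxy rests on compound 3, which leaves open whether methoxy would give a high reading alongside thiophen-2-yl or unsubstituted benzyl.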